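Swapping the Benzyl Group in an Inactive Pair

The compounds below may be only part of what the source reports. "The series", "measured", "known", "first", "only" and "open" are said of these compounds alone.

Of the compounds shown here, two sharing one core have been tested in a functional assay on HeLa cells (Homo sapiens) for cytotoxicity; a higher number here means a weaker inhibitor, a lower number a stronger inhibitor. Compound 1 `Cc1n[nH]c2nnc(N)c-2c1C` reaches only a limit of this assay, compound 1 giving > 100000 nM. Compound 2 `Nc1nn(Cc2ccccc2)c2nnc(-c3ccccc3)c(-c3ccccc3)c12` likewise reaches only a limit, compound 2 giving > 100000 nM. Both results sit at the limit of > 100000 nM in this assay, at which 2 of the 2 values shown sit. Compound 3 `Nc1nn(COCCO)c2nnc(-c3ccccc3)c(-c3ccccc3)c12` differs from compound 2 in one place: 2-hydroxyethoxy in place of phenyl on a saturated chain carbon bound to an aromatic nitrogen. Since compound 2 shows no numbered value, no step size can be read from the data. Compound 3 is expected to stay at the limit, with an expected step of a number no higher from compound 2 to compound 3 (the limit leaves the size open). Compound 3 is thus estimated at 100000 nM, between 30000 nM and 300000 nM.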

Compound 3, half-maximal inhibitory concentration: > 100000 nM
Compound 3 ended at the assay's limit; the forecaster's own chance of this, stated with the estimate: 80%; the middle value sits exactly at the limit.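

No step can be read from compound 2 to compound 3, since each stands only at a limit of this assay: the limit of > 100000 nM in this assay, at which 3 of the 3 values shown sit.

The compounds shown leave open whether benzyl and (2-hydroxyethoxy)methyl differ at all in this assay.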